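Naphthalenyl Replaces Chlorophenoxy: Cytotoxicity Expectation for Compound 3

The source may report more compounds than this note shows. Statements on the series, on what has been measured and on what is new or still open speak of the compounds shown alone.

Two measured compounds share one core and differ in a single place. Compound 1 `Fc1ccc(-c2ccc3c(NCCCNCc4ccco4)ccnc3c2)cc1` carries a 4-fluorophenyl there, and in an ADME assay on HepG2 cells (Homo sapiens) for cytotoxicity, read by luminescence, CellTiter-Glo and ATP content, with a stated time of 72 h (on this read-out lower numbers stand for an effect already at smaller amounts and higher numbers for an effect only at larger amounts of compound), compound 1 gives 7760 nM. Compound 2 `Clc1ccc(Oc2ccc3c(NCCCNCc4ccco4)ccnc3c2)cc1` carries a 4-chlorophenoxy in that place, and in this assay compound 2 gives 7800 nM. Among these two numbers compound 2 stands highest, yet a 1.0-fold higher number from compound 1 to compound 2 (0.00 log units; within the scatter), so the two values cannot be told apart. Compound 3 `c1coc(CNCCCNc2ccnc3cc(-c4cccc5ccccc45)ccc23)c1` has not yet been measured; it differs from compound 2 in that (naphthalen-1-yl in place of 4-chlorophenoxy on an aromatic carbon). Within the data shown here, the only measured step that bears on this place is a 1.0-fold higher number from compound 1 to compound 2 (0.00 log units; within the scatter), which showed no movement. Because a 1.0-fold higher number from compound 1 to compound 2 (0.00 log units; within the scatter) left the number essentially unchanged, the step to compound 3 is expected to stay within the scatter as well, with a 1.2-fold lower number from compound 2 to compound 3 (0.08 log units; within the scatter) as the estimated change. Compound 3 is therefore expected to give 6500 nM in this assay, within a range from 2500 nM to 16000 nM.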

Compound 3, half-maximal effective concentration: 5600 nM
Compound 3: middle estimate off by 1.2-fold (0.06 log units), on the high side, and the stated range covers the measured number.
By their numbers in this assay, from the lowest: compounds 3, 1 and 2 (each within the scatter of the next).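

The earlier pair showed only that a 4-fluorophenyl and a 4-chlorophenoxy could not be told apart at this position; compound 3 extends that finding to a fused carbon group with two six-membered aromatic rings. The change to naphthalen-1-yl gives a 1.4-fold lower number from compound 2 to compound 3 (0.14 log units; within the scatter) and a 1.4-fold lower number from compound 1 to compound 3 (0.14 log units; within the scatter) in this assay and so leaves all three compounds within the scatter of one another, even though the entering group has more heavy atoms and no oxygen, chlorine or hydrogen-bond acceptor. Nothing measured here explains this lack of separation.

Going by these compounds, all three groups at this position carry carbon-only aromatic rings, so whether an amine, a carboxylic acid or a small methyl group there would move the number remains open. Also open, on these data alone, is whether a longer chain in place of these aromatic groups would leave the number in this assay unchanged.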